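The compounds below may be only part of what the source reports. "The series", "measured", "known", "first", "only" and "open" are said of these compounds alone.

Measured compounds in an assay on HEK293 cells for inhibition of potassium/sodium hyperpolarization-activated cyclic nucleotide-gated channel 4 (Homo sapiens), with a stated time of 30 min; on this read-out higher numbers stand for weaker inhibition and lower numbers for stronger inhibition:

- Compound 1, `CN1CCN(C2(CNC(=O)c3ccccc3OCc3ccccc3)Cc3ccccc3C2)CC1`: 2510 nM
- Compound 2, `CCOc1ccccc1C(=O)NCC1(N2CCN(CC)CC2)CCCCC1`: 158 nM
- Compound 3, `CCOc1ccccc1C(=O)NCC1(N2CCN(C3CC3)CC2)CCCCC1`: 316 nM

Compound 3 has the second highest of the three numbers in this assay. Its nearest neighbour is compound 2, whose number is lower, but the step of a 2.0-fold higher number from compound 2 to compound 3 (0.30 log units; within the scatter) is within the scatter, so the two cannot be told apart. Compound 1, built on a different core, gives a number well above that of compound 3, and that gap lies beyond the scatter.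

Compound 4, `CCOc1ccccc1C(=O)NCC1(N2CCN(C3CCC3)CC2)CCCCC1`, differs from compound 3 in one place: cyclobutyl in place of cyclopropyl on an amine nitrogen in a ring. Among the compounds with values here, the only measured step that bears on this is the one where the same ring nitrogen changed from carrying ethyl to carrying cyclopropyl, a 2.0-fold higher number from compound 2 to compound 3 (0.30 log units; within the scatter), which stayed within the scatter. Growing the ring on that nitrogen by one carbon is a change of the same kind, so no step beyond the scatter is expected in this assay, with at most a drift toward a higher number. For compound 4 the estimated value is 400 nM, with a range from 150 nM to 1100 nM. This estimate corresponds to an expected step of a 1.3-fold higher number from compound 3 to compound 4 (0.10 log units; within the scatter).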

Compound 4, half-maximal inhibitory concentration: 794 nM
The estimate for compound 4 lay 2.0-fold (0.30 log units) below the measured number, and the stated range covers the measured number.
By their numbers in this assay, from the lowest: compounds 2 and 3 (each within the scatter of the next); then compound 4; then compound 1.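

The earlier pair made this amine nitrogen look tolerant of change, but in this assay the step is a 2.5-fold higher number from compound 3 to compound 4 (0.40 log units; beyond the scatter), so a small change in the carbon ring on this nitrogen can move the number beyond the scatter, toward weaker inhibition. Set against the ethyl compound, the step is a 5.0-fold higher number from compound 2 to compound 4 (0.70 log units; beyond the scatter), which is also modest but beyond the scatter, so cyclobutyl stands apart from both ethyl and cyclopropyl, while those two cannot be told apart from each other. No measurement available here accounts for this rise in the number.

The compounds shown leave open whether a still larger ring such as cyclopentyl, or a longer chain such as propyl, on this nitrogen would raise the number further, and what a plain hydrogen there would give. They also leave open whether the cyclobutyl change would have a similar effect on the core of compound 1, which differs from the other compounds in more than one place and so offers no direct comparison.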